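The source may report more compounds than this note shows. Statements on the series, on what has been measured and on what is new or still open speak of the compounds shown alone.

Measured in a physicochemical assay for lipophilicity, using the shake flask method, measured as octanol-water partition, at pH 7.4; on this read-out lower numbers stand for lower lipophilicity and higher numbers for higher lipophilicity:
- compound 1 `CC(=O)N[C@@H]1CCC[C@H](C(=O)Nc2cc(-c3cnn(C)c3C)c(Cl)cn2)C1`: 2.6
- compound 2 `CC(=O)N[C@@H]1CCC[C@H](C(=O)Nc2cc(-c3cnc4n3CCCC4)c(Cl)cn2)C1`: 2.7

Compound 2 stands at 2.7, within the scatter of compound 1. The next case is compound 3 `CC(=O)N[C@@H]1CCC[C@H](C(=O)Nc2cc(-c3cnc(C)n3C)c(Cl)cn2)C1`: a group of 7 heavy atoms (5 carbon, 2 nitrogen; one five-membered aromatic ring with 2 hetero atoms) in place of a group of 9 heavy atoms (7 carbon, 2 nitrogen; one five-membered aromatic ring with 2 hetero atoms, one six-membered non-aromatic ring with 1 hetero atom), on an aromatic carbon, with 1,2-dimethyl-1H-imidazol-5-yl entering opposite the ring nitrogen. Within the data shown here, the only measured step that bears on this is a number 0.10 log units higher from compound 1 to compound 2 (within the scatter), an exchange between groups of the same two sizes, though the smaller group there is a different one. That step offers weak guidance, so a modest drop in this assay is expected, with a return to the smaller group size. The expected change is a number 0.40 log units lower from compound 2 to compound 3 (beyond the scatter). Compound 3 is estimated at 2.3, with an expected range of 1.9 to 2.7.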

Compound 3, distribution coefficient: 2.2
Compound 3: the middle estimate sits 0.10 log units above what was measured; low and high end bracket the measured number.
By their numbers in this assay, from the lowest: compound 3; then compounds 1 and 2 (each within the scatter of the next).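

In this assay, 1,2-dimethyl-1H-imidazol-5-yl in place of 1,5-dimethyl-1H-pyrazol-4-yl gives a number 0.40 log units lower from compound 1 to compound 3 (beyond the scatter) with no change in heavy-atom count, so on this aromatic carbon, opposite the ring nitrogen, the identity of the group counts and not only its size. Among these compounds, the exchange of the larger group for the imidazole gives a number 0.50 log units lower from compound 2 to compound 3 (beyond the scatter), whereas the one earlier step showed no shift beyond the scatter. No measurement on hand accounts for this difference. Open, going by these compounds, is how an unsubstituted imidazole or a phenyl on this carbon would compare with these groups.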